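Removing the Amide Hydrogen: Compound 3 to Compound 4

The source may report more compounds than this note shows. Statements on the series, on what has been measured and on what is new or still open speak of the compounds shown alone.

Measured so far in a toxicity assay on L02 cells (Homo sapiens) for inhibition, read by CCK-8 assay, with a stated time of 72 h; on this read-out lower numbers stand for stronger inhibition and higher numbers for weaker inhibition:
compound 1, `CC(C)(C)OC(=O)N1CCN(C(=O)Cn2cc(CN3C(=O)C(=O)c4c(Cl)ccc(Cl)c43)nn2)CC1`: 42000 nM
compound 2, `O=C1C(=O)N(Cc2cn(CC(=O)N3CCOCC3)nn2)c2c(Cl)ccc(Cl)c21`: its result is a limit of the assay, > 128000 nM
compound 3, `O=C(Cn1cc(CN2C(=O)C(=O)c3c(Cl)ccc(Cl)c32)nn1)NC1CCCCC1`: 83900 nM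

On these numbers compound 3 gives the highest of the two numbers in this assay; compound 1 lies close, within the scatter. Compound 4 is `O=C1C(=O)N(Cc2cn(CC(=O)N3CCCCC3)nn2)c2c(Cl)ccc(Cl)c21`, and it differs from compound 3 by one change: piperidin-1-yl in place of cyclohexylamino on a carbonyl carbon. Among the compounds with values here, the only measured step at this carbonyl carbon, an at least 1.5-fold lower number from compound 2 to compound 3 (0.18 log units; that floor lies within the scatter), was no larger than the scatter, and it concerned (the limit of > 128000 nM in this assay, at which 1 of the 3 values shown sits). That gives no sign that exchanging a cyclohexylamino for a piperidin-1-yl would move the number in this assay beyond the scatter in either direction. For compound 4 the estimate is therefore 80000 nM, within 30000 nM to 200000 nM, and the expected step of a 1.0-fold lower number from compound 3 to compound 4 (0.02 log units; within the scatter) is not beyond the scatter.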

Compound 4, half-maximal inhibitory concentration: 39300 nM
For compound 4 the middle estimate is 2.0-fold (0.31 log units) above the measured one, and the stated range covers the measured number.
By their numbers in this assay, from the lowest: compounds 4, 1 and 3 (each within the scatter of the next, the first and the last beyond it). At a limit, above all of these: compound 2.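

In this assay, the group on this carbonyl carbon now gives a step beyond the scatter: a 2.1-fold lower number from compound 3 to compound 4 (0.33 log units; beyond the scatter), with the hydrogen-bond donor of cyclohexylamino gone. Swapping the ring oxygen-bearing morpholin-4-yl for piperidin-1-yl gives an at least 3.2-fold lower number from compound 2 to compound 4 (0.51 log units; beyond the scatter). That step is only a floor, as the result of compound 2 is a limit of the assay: the limit of > 128000 nM in this assay, at which 1 of the 4 values shown sits.

Going by these compounds, whether the lower number follows the lost amide hydrogen or the piperidine ring itself remains open. A pyrrolidin-1-yl or diethylamino group at this carbonyl carbon could help separate the two.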